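Working notes: step from compound 2 to compound 3

This account rests on a few compounds, and the source may have more. Where it says the series, first, only, none or still open, it means among the compounds named here.

Measured so far in a functional assay on FM3A cells (Mus musculus) for cytotoxicity; on this read-out lower numbers stand for an effect already at smaller amounts and higher numbers for an effect only at larger amounts of compound:
- compound 1 `CCCCOOC1(OOC)CCCCCCCCCCC1`: 20000 nM
- compound 2 `COOC1(OOCCC(=O)OC)CCCCCCCCCCC1`: 1400 nM

Compound 2 holds the lower of the two numbers, at 1400 nM, and compound 1 stands at 20000 nM. Compound 3 `COOC1(OC)CCCCCCCCCCC1` has not yet been measured in this assay. It differs from compound 2 by methyl in place of 2-(methoxycarbonyl)ethoxy on an oxygen on a saturated carbon.

Within the data shown here, one measured step bears on this change: a 14-fold lower number from compound 1 to compound 2 (1.15 log units; beyond the scatter), large and beyond the scatter, with methoxycarbonyl in place of ethyl. Compound 3 also lacks the methoxycarbonyl, as does compound 1 at 20000 nM, so a large step of similar size towards a higher number is expected in this assay. Among the measured compounds shown here, this rests on a single pair, and no measured step covers methyl in place of the whole chain, so the range stays wide.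

Compound 3 is estimated at 10000 nM, with an expected range of 2500 nM to 40000 nM. The expected change is a 7.1-fold higher number from compound 2 to compound 3 (0.85 log units; beyond the scatter).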

Compound 3, half-maximal effective concentration: 19000 nM
For compound 3 the middle estimate is 1.9-fold (0.28 log units) below the measured one; the range from low to high includes it.
By their numbers in this assay, from the lowest: compound 2; then compounds 3 and 1 (each within the scatter of the next).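

In this assay, methyl in place of 2-(methoxycarbonyl)ethoxy on an oxygen on a saturated carbon gives a 14-fold higher number from compound 2 to compound 3 (1.13 log units; beyond the scatter), so the low number of compound 2 is lost when this chain leaves. Methyl in place of butoxy at the same place gives a 1.1-fold lower number from compound 1 to compound 3 (0.02 log units; within the scatter), so among these three compounds the length of a chain without methoxycarbonyl makes no difference beyond the scatter, and only compound 2, the one compound carrying methoxycarbonyl, stands apart. No measurement bears on why this chain lowers the number.

The compounds shown leave open whether the low number depends on the methoxycarbonyl itself, which a carboxylic acid or an amide at the end of the same chain would test. They also leave open how the number depends on the distance of the methoxycarbonyl from the core, which a longer chain ending in that group would address.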